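The compounds below may be only part of what the source reports. "The series", "measured", "known", "first", "only" and "open" are said of these compounds alone.

Measured so far in a functional assay on PC-3 cells (Homo sapiens) for inhibition, read by sulforhodamine B assay, with a stated time of 48 h; on this read-out lower numbers stand for higher toxicity in this test and higher numbers for lower toxicity in this test:
Compound 1 `Cc1ccc(C2=NN(c3ccc(S(C)(=O)=O)cc3)C(=O)CC2)cc1`: > 100000 nM (limit)
Compound 2 `Cc1cc(O)ccc1C1=NN(c2ccc(S(C)(=O)=O)cc2)C(=O)CC1`: > 100000 nM (limit)

Compound 2 has no number in this assay and stands only at the limit of the assay. Within the data shown here, the series so far offers only the limit of > 100000 nM in this assay, at which 2 of the 2 values shown sit, as evidence. Among the measured compounds shown here, the one measured change gives a step that the two limits leave unreadable from compound 1 to compound 2 and so leaves no size to carry forward.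

Compound 3 `CCc1ccc(C2=NN(c3ccc(S(C)(=O)=O)cc3)C(=O)CC2)cc1` differs from compound 2 at one place, with 4-ethylphenyl in place of 4-hydroxy-2-methylphenyl on a carbon with a double bond to nitrogen.

With no readable step to draw on, no change beyond the scatter is expected in this assay, and the most likely result is the same limit. The estimated move is a number no higher from compound 2 to compound 3 (the limit leaves the size open) and it is expected to stay within the scatter. For compound 3 the estimate is 100000 nM with an expected range from 40000 nM to 200000 nM in case a number is reported.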

Compound 3, concentration lethal to 50% of the cells: > 100000 nM
Compound 3: a limit, no number (the forecaster's own chance of this, stated with the estimate: 85%); the middle value lies on the limit itself.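

Among these compounds, compound 1, compound 2 and compound 3 all give only a limit in this assay, so no step among them can be read: the limit of > 100000 nM in this assay, at which 3 of the 3 values shown sit.

The compounds shown leave open whether any group at this place on the shared core gives a number in this read-out, and how large such a step would be.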